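The compounds below may be only part of what the source reports. "The series", "measured", "known", "first", "only" and "open" are said of these compounds alone.

Of the compounds shown here, three sharing one core have been tested in a functional assay on HepG2 cells (Homo sapiens) for cytotoxicity, read by MTT assay, with a stated time of 72 h; on this read-out higher numbers stand for weaker inhibition and lower numbers for stronger inhibition. Compound 1 `COc1cc2ncnc(Nc3ccc(F)c(Cl)c3)c2cc1NC(=O)N/N=C/c1cccc(Br)c1` gives "not active" (no number reported), with no number reported. Compound 2 `COc1cc2ncnc(Nc3ccc(F)c(Cl)c3)c2cc1NC(=O)N/N=C/c1ccc(C#N)cc1` gives 34100 nM, and compound 3 `COc1ccc(/C=N/NC(=O)Nc2cc3c(Nc4ccc(F)c(Cl)c4)ncnc3cc2OC)cc1` gives 21300 nM. For the measured compounds named here, only two numbers therefore exist, and compound 3 has a single neighbour among them: the gap is a 1.6-fold lower number from compound 2 to compound 3 (0.20 log units; within the scatter).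

Compound 4 `COc1cc2ncnc(Nc3ccc(F)c(Cl)c3)c2cc1NC(=O)N/N=C/c1ccc(O)c(Br)c1` has 3-bromo-4-hydroxyphenyl in place of 4-methoxyphenyl on a carbon with a double bond to nitrogen. Just one measured step bears on this exchange, the swap of cyano for methoxy on an aromatic carbon, and its size is a 1.6-fold lower number from compound 2 to compound 3 (0.20 log units; within the scatter). Going by the values given here, no measured step isolates the bromine or the hydroxy group. The ring of compound 1 also carries a bromine, and compound 1 gives "not active" (no number reported) in this assay, so a result without a number remains possible. With so little evidence, no clear shift in either direction is expected beyond the scatter. The expected change is a 1.1-fold lower number from compound 3 to compound 4 (0.03 log units; within the scatter). For compound 4 the estimated value is 20000 nM, with an expected range from 7000 nM to 60000 nM.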

Compound 4, half-maximal inhibitory concentration: 23800 nM
Estimate against measurement, compound 4: 1.2-fold (0.08 log units) below; measured number inside the range.
By their numbers in this assay, from the lowest: compounds 3, 4 and 2 (each within the scatter of the next).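

In this assay, the exchange on the carbon with a double bond to nitrogen leaves the number within the scatter: 3-bromo-4-hydroxyphenyl in place of 4-methoxyphenyl gives a 1.1-fold higher number from compound 3 to compound 4 (0.05 log units; within the scatter), and in place of 4-cyanophenyl it gives a 1.4-fold lower number from compound 2 to compound 4 (0.16 log units; within the scatter). The ring of compound 4 carries a bromine and still returns a number, whereas compound 1, whose ring also carries a bromine, gives "not active" (no number reported), so a bromine on this ring does not by itself go with a result without a number. No measurement shown accounts for either the closeness of these numbers or the missing number of compound 1.

The compounds shown do not separate the bromine from the hydroxy group in compound 4, so the part each plays at this position remains open. Also open, on these data alone, is whether a ring bearing an amine or a carboxylic acid at this place would move the number beyond the scatter, as none of the steps among compounds 2, 3 and 4 does.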